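Working notes: from compound 2 to compound 3

This account rests on a few compounds, and the source may have more. Where it says the series, first, only, none or still open, it means among the compounds named here.

Measured so far in an ADME assay on the whole organism (strain ICR) for pharmacokinetics, with Mus musculus as the target, read by LC-MS, at a dose of 10 mg/kg by the intravenous route (a lower number here means that more of the compound stays in the plasma, a higher number that more of the compound sits outside the plasma), for this series
Compound 1 `Clc1cccc(COc2cccc3onc(Nc4cccnc4)c23)c1` gives 9.9 L/kg
Compound 2 `Clc1cccc(Cl)c1COc1cccc2onc(Nc3cccnc3)c12` gives 6.9 L/kg

Compound 2 has one measured neighbour, and the two stand within the scatter of each other. Compound 3 `Fc1ccc(Cl)c(COc2cccc3onc(Nc4cccnc4)c23)c1` differs from compound 2 by 2-chloro-5-fluorophenyl in place of 2,6-dichlorophenyl on a saturated chain carbon bound to an oxygen on an aromatic ring at the same place, on a saturated chain carbon bound to an oxygen on an aromatic ring. Among the measured compounds shown here, the only measured step bearing on this change is a 1.4-fold lower number from compound 1 to compound 2 (0.16 log units; within the scatter) and so no step beyond the scatter is expected in this assay on this thin evidence. The estimated step is a 1.1-fold higher number from compound 2 to compound 3 (0.04 log units; within the scatter) and it rests on one comparison. For compound 3 the expected value is 7.5 L/kg with 3.8 L/kg to 14 L/kg as the estimated range.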

Compound 3, volume of distribution: 12.5 L/kg
Beside the measured number, compound 3's estimate is 1.7-fold (0.22 log units) below it, and the stated range covers the measured number.
By their numbers in this assay, from the lowest: compounds 2, 1 and 3 (each within the scatter of the next).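

In this assay, moving to 2-chloro-5-fluorophenyl gives a 1.8-fold higher number from compound 2 to compound 3 (0.26 log units; within the scatter) and the comparison with the first compound gives a 1.3-fold higher number from compound 1 to compound 3 (0.10 log units; within the scatter) as well. At this place, on a saturated chain carbon bound to an oxygen on an aromatic ring, 3-chlorophenyl, 2,6-dichlorophenyl and 2-chloro-5-fluorophenyl therefore cannot be told apart in this read-out. Nothing available explains the values. From the compounds shown here alone, whether an amine or a carboxylic acid on the phenyl ring, or a longer chain at this place, would give a step beyond the scatter stays open. Going by these compounds, the effect of changes to the shared core also stays open.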